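The source may report more compounds than this note shows. Statements on the series, on what has been measured and on what is new or still open speak of the compounds shown alone.

Measured compounds:
Compound 1 `O=C(O)COc1ccc(Cl)cc1C#Cc1ccncc1` gives 601 nM in an assay on CHO cells for displacement of a labelled ligand from prostaglandin D2 receptor 2 (Homo sapiens), read by scintillation counting; on this read-out higher numbers stand for weaker inhibition and lower numbers for stronger inhibition.
Compound 2 `Cc1ccc(S(=O)(=O)N2CCN(C)CC2)cc1C#Cc1cc(Cl)ccc1OCC(=O)O` gives 21 nM in this assay.
Compound 3 `CCCS(=O)(=O)c1ccc(F)c(C#Cc2cc(Cl)ccc2OCC(=O)O)c1` gives 3.4 nM in this assay.

Among these three numbers compound 2 stands second highest. Compound 3 lies below it, and that gap is beyond the usual scatter of repeated measurements; compound 1 lies above it, also beyond the scatter. All three share the same core, and the two compounds carrying a sulfonyl group on the outer ring, compound 2 and compound 3, give the lower numbers.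

Compound 4 `CNS(=O)(=O)c1ccc(C)c(C#Cc2cc(Cl)ccc2OCC(=O)O)c1` is the next compound to be tested. It differs from compound 2 in one place: methylamino in place of 4-methylpiperazin-1-yl on a sulfonyl sulfur. The sulfonyl group itself stays. Since compound 3, with a different partner on its sulfonyl sulfur, gives 3.4 nM, a change at this sulfur need not raise the number. The expected step from compound 2 to compound 4 is a 1.8-fold lower number from compound 2 to compound 4 (0.24 log units; within the scatter), small, downward or none beyond the scatter. Compound 4 is therefore expected to give about 12 nM in this assay, within a range from 4 nM to 40 nM.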

Compound 4, inhibition constant: 10 nM
Compound 4: the middle estimate sits 1.2-fold (0.08 log units) above what was measured; low and high end bracket the measured number.
By their numbers in this assay, from the lowest: compound 3; then compound 4; then compound 2; then compound 1.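

At this sulfonyl sulfur, the 4-methylpiperazin-1-yl ring can be replaced by the much smaller methylamino group without losing binding: in this assay the change gives a 2.1-fold lower number from compound 2 to compound 4 (0.32 log units; beyond the scatter), a modest step that only just clears the usual scatter. For the compounds shown here, the earlier compounds could not show this, as no two of them differed in just one place, so this is the first direct reading of a change at this sulfur. The change removes a ring and adds a hydrogen-bond donor at the same time, and nothing measured here explains the step.

The compounds shown cannot separate those two parts of the change. From the compounds shown here alone, that question stays open for a dimethylamino group, which has no hydrogen on its nitrogen, and for a longer chain such as ethylamino on the same sulfur.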